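Adding a methyl to compound 3

The source may report more compounds than this note shows. Statements on the series, on what has been measured and on what is new or still open speak of the compounds shown alone.

Compound 1 `Cc1ccc(-c2noc(CCCCCCC(=O)NO)n2)cc1` gives 1360 nM
Compound 2 `Cc1ccc(-c2noc(CCCCCCC(=O)Nc3ccccc3N)n2)cc1` gives 460 nM
Compound 3 `O=C(CCCCCCc1nc(-c2ccccc2)no1)C(F)(F)F` gives 410 nM

In a functional assay on U-937 cells (Homo sapiens) for antiproliferative activity, read by MTT assay, with a stated time of 72 h (on this read-out lower numbers stand for stronger inhibition and higher numbers for weaker inhibition), compound 3 lies within the scatter of compound 2 and lower, beyond the scatter, than compound 1. Compound 4 `Cc1ccc(-c2noc(CCCCCCC(=O)C(F)(F)F)n2)cc1` differs from compound 3 by one change, methyl in place of hydrogen on an aromatic carbon. For the measured compounds named here, the only measured step, a 3.0-fold lower number from compound 1 to compound 2 (0.47 log units; beyond the scatter), is a change on an amide-type nitrogen. Going by the values given here, it therefore bears only weakly, and no measured step alters this aromatic carbon. In this assay the expected change is a 1.0-fold lower number from compound 3 to compound 4 (0.01 log units; within the scatter) and so no step beyond the scatter. Compound 4 is estimated at 400 nM with 180 nM to 900 nM as the expected range.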

Compound 4, half-maximal inhibitory concentration: 3730 nM
Compound 4: the middle estimate sits 9.3-fold (0.97 log units) below what was measured; the measured number lies above the stated range.
By their numbers in this assay, from the lowest: compounds 3 and 2 (each within the scatter of the next); then compound 1; then compound 4.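

In this assay the change from phenyl to 4-methylphenyl brings a 9.1-fold higher number from compound 3 to compound 4 (0.96 log units; beyond the scatter) and so shows that this aromatic carbon, untouched by any earlier step, is not indifferent to methyl. With the 4-methylphenyl held fixed, trifluoromethyl on the carbonyl carbon gives an 8.1-fold higher number from compound 2 to compound 4 (0.91 log units; beyond the scatter) against (2-aminophenyl)amino and a 2.7-fold higher number from compound 1 to compound 4 (0.44 log units; beyond the scatter) against hydroxyamino, which places it behind both groups. No available evidence accounts for these steps. Still open, going by these compounds, is whether a chlorine atom or a methoxy group on this carbon would act as methyl does, and whether the methyl step recurs with hydroxyamino or (2-aminophenyl)amino on the carbonyl carbon.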